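A second fluoro on compound 2

The source may hold more compounds than are shown below. What is called first, only, known or untested is meant among the compounds shown, and "the series" means these compounds.

Measured in a functional assay on HT-29 cells (Homo sapiens) for antiproliferative activity, read by sulforhodamine B assay, with a stated time of 48 h; on this read-out higher numbers stand for weaker inhibition and lower numbers for stronger inhibition:
compound 1 `O=C1NCCN1c1ccc(S(=O)(=O)Nc2ccc(C3CCCCC3)cc2)cc1`: > 1000 nM (a limit)
compound 2 `O=C1NCCN1c1ccc(S(=O)(=O)Nc2ccc(F)cc2)cc1`: 370 nM
compound 3 `CCCCCCCc1ccc(NS(=O)(=O)c2ccc(N3CCNC3=O)cc2)cc1`: > 1000 nM (a limit)

Going by the values given here, compound 2 holds the only actual number of the three, 370 nM. Compound 1 and compound 3 each sit at a limit.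

Compound 4 `O=C1NCCN1c1ccc(S(=O)(=O)Nc2ccc(F)c(F)c2)cc1` differs from compound 2 by one change: fluoro in place of hydrogen on an aromatic carbon. Put simply, 4-fluorophenyl becomes 3,4-difluorophenyl.

Two measured steps alter a group on this same aromatic ring: an at least 2.7-fold lower number from compound 1 to compound 2 (0.43 log units; beyond the scatter), and an at least 2.7-fold higher number from compound 2 to compound 3 (0.43 log units; beyond the scatter). The sizes of both rest on (the limit of > 1000 nM in this assay, at which 2 of the 3 values shown sit). Each exchanges fluoro for a whole cyclohexyl or heptyl group, whereas compound 4 keeps the fluoro and gains a second one. Among the compounds with values here, no measured step adds a fluoro in place of hydrogen, so these steps give only loose guidance, and no shift beyond the scatter is expected in this assay.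

The expected change is a 1.1-fold lower number from compound 2 to compound 4 (0.05 log units; within the scatter).

For compound 4 the estimated value is 330 nM, with an expected range from 120 nM to 900 nM.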

Compound 4, half-maximal inhibitory concentration: 350 nM
Compound 4: the middle estimate sits 1.1-fold (0.03 log units) below what was measured; the range from low to high includes it.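

In this assay, the new change gives a 1.1-fold lower number from compound 2 to compound 4 (0.02 log units; within the scatter), so placing a fluoro ortho to the existing fluoro leaves activity on these cells effectively unchanged. Going by these compounds alone, this is the first step on this ring with a real number at both ends, and it shows that this position accepts a fluoro in place of hydrogen without a loss that can be told from the scatter. The earlier steps on the ring could only show a direction and a minimum size, as each has one end at a limit: the limit of > 1000 nM in this assay, at which 2 of the 4 values shown sit.

From the compounds shown here alone, what stays open is how this same position responds to a group other than fluoro, such as chloro, methoxy, trifluoromethyl or an amine. A single fluoro here also cannot show whether the position would respond to any substituent at all.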